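Compound 3: benzyloxy in place of anilino

This account rests on a few compounds, and the source may have more. Where it says the series, first, only, none or still open, it means among the compounds named here.

Of the compounds shown here, two with the shared core have been measured in an ADME assay on microsomes from liver (Mus musculus) for metabolic stability, read by LC-MS, with NADPH named in the record, with a stated time of 60 min, tested at 1 uM, in the absence of a further agent; a higher number here means that more of the compound is left, a lower number that less of the compound is left. Compound 1 (`COc1ccc(-c2c(C)nc3c(N4CC[C@@H](NC(=O)NC(C)C)C4)cc(C)nn23)cc1OC`) gives > 95%, which is a limit and not a number. Compound 2 (`COc1ccc(-c2c(C)nc3c(N4CC[C@@H](NC(=O)Nc5ccccc5)C4)cc(C)nn23)cc1OC`) gives > 95%, which is also a limit. Compound 2 therefore stands with the limit of > 95% in this assay, at which 2 of the 2 values shown sit, so no number places it within the series.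

Compound 3 (`COc1ccc(-c2c(C)nc3c(N4CC[C@@H](NC(=O)OCc5ccccc5)C4)cc(C)nn23)cc1OC`) is still unmeasured. Its difference from compound 2 is benzyloxy in place of anilino on a carbonyl carbon. In other words, phenylcarbamoyl becomes benzyloxycarbonyl.

Among the measured compounds shown here, the only measured step is a step that the two limits leave unreadable from compound 1 to compound 2. That step offers no size to carry over, and it is not the same change as the one made here. The expectation therefore starts from compound 2 with > 95% and allows for a modest fall in this assay, with considerable uncertainty about its size. The estimated change is a number at least 10 percentage points lower from compound 2 to compound 3 (that floor lies within the scatter). For compound 3 the expected reading is 85%, with an estimated range from 55% to 98%.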

Compound 3, percent of the compound remaining: > 95%
Compound 3: no number, only a limit; the forecaster's own chance of this, stated with the estimate: 35%; middle value at least 10 percentage points away from the limit.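

In this assay compound 3 gives > 95% as a limit and not a number. Among the compounds shown here, no step among compound 1, compound 2 and compound 3 can be read, as all three rest on one limit: the limit of > 95% in this assay, at which 3 of the 3 values shown sit. The compounds shown leave open how much of each compound remains, and whether benzyloxy in place of anilino changes that reading at all.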